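Ring-nitrogen aryl swap from compound 2 to compound 4

The source may report more compounds than this note shows. Statements on the series, on what has been measured and on what is new or still open speak of the compounds shown alone.

The shared core is common to compound 1 `Nc1scc(CN2CCN(c3ccc(Cl)c(C(F)(F)F)c3)CC2)c1C(=O)c1ccc(Cl)cc1`, compound 2 `Nc1scc(CN2CCN(c3ccc(OC(F)(F)F)cc3)CC2)c1C(=O)c1ccc(Cl)cc1` and compound 3 `Nc1scc(CN2CCC(c3ccc(Cl)cc3)CC2)c1C(=O)c1ccc(Cl)cc1`. In a functional assay on CHO cells with adenosine receptor A1 (Homo sapiens) as the target, read by cAMP accumulation and immunoassay, with a stated time of 6 min, tested at 0.1 uM (on this read-out higher numbers stand for a weaker effect at the one concentration tested and lower numbers for a stronger effect), compound 1 gives -12%, compound 2 gives -13% and compound 3 gives -2.3%. Compound 2 holds the lowest of the three numbers; its nearest neighbour is compound 1, within the scatter, and its furthest is compound 3, beyond the scatter.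

Compound 4 `Nc1scc(CN2CCN(c3ccc(F)c(Cl)c3)CC2)c1C(=O)c1ccc(Cl)cc1` is not yet measured. It differs from compound 2 as 3-chloro-4-fluorophenyl in place of 4-(trifluoromethoxy)phenyl on an amine nitrogen in a ring. Among the compounds with values here, the one measured step that bears on this is the aryl exchange on the same amine nitrogen in a ring: a number 1 percentage points lower from compound 1 to compound 2 (within the scatter). That exchange left the read-out in this assay unchanged within the scatter, so no step beyond the scatter is expected here either, with the aryl on the amine nitrogen in a ring again varied and everything else held.

Compound 4 is therefore expected to show a number 3 percentage points higher from compound 2 to compound 4 (within the scatter) in this assay. The estimate for compound 4 is -10%, with a range from -25% to 5%.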

Compound 4, a percentage reported as activity, at one concentration (the size of the read-out at that concentration, not a potency): -21%
Estimate against measurement, compound 4: 11 percentage points above, and the stated range covers the measured number.
By their numbers in this assay, from the lowest: compounds 4, 2, 1 and 3 (each within the scatter of the next, the first and the last beyond it).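

In this assay a third aryl group on the amine nitrogen in a ring, 3-chloro-4-fluorophenyl, gives a number 8 percentage points lower from compound 2 to compound 4 (within the scatter) and also a number 9 percentage points lower from compound 1 to compound 4 (within the scatter). The position thus takes this group of 8 heavy atoms with 0 hydrogen-bond acceptors as readily as 4-(trifluoromethoxy)phenyl with 11 heavy atoms and 1 hydrogen-bond acceptor, so the oxygen of the leaving group is not required to keep the read-out at this one concentration. The three aryl groups on this nitrogen cannot be ranked against one another on these numbers. Nothing at hand explains these steps.

From the compounds shown here alone, all three aryl groups carry halogen, so it remains open how an unsubstituted phenyl, or an aryl bearing a carboxylic acid or an amine, would read here. A single concentration also leaves any difference in potency among these compounds open.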